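A new group on the same ring nitrogen

The source may report more compounds than this note shows. Statements on the series, on what has been measured and on what is new or still open speak of the compounds shown alone.

Measured in a functional assay on MGC-803 cells (Homo sapiens) for inhibition, read by MTT assay, with a stated time of 48 h; a higher number here means a weaker inhibitor, a lower number a stronger inhibitor:
- compound 1 `COc1ccc(-c2coc3cc(OCCCSC(=S)N4CCN(C)CC4)ccc3c2=O)cc1`: 21900 nM
- compound 2 `COc1ccc(-c2coc3cc(OCCCSC(=S)N4CCN(c5ccccn5)CC4)ccc3c2=O)cc1`: 42000 nM

Going by the values given here, only two numbers exist so far, and compound 2 cannot be ranked against compound 1, since the gap between them lies within the scatter. Compound 3 `COc1ccc(-c2coc3cc(OCCCSC(=S)N4CCN(C(=O)OC(C)(C)C)CC4)ccc3c2=O)cc1` has not been measured yet. It carries tert-butoxycarbonyl in place of pyridin-2-yl on an amine nitrogen in a ring, so the count of what changes is tert-butoxycarbonyl in place of pyridin-2-yl on an amine nitrogen in a ring.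

Among the compounds with values here, one measured step bears on this nitrogen: a 1.9-fold higher number from compound 1 to compound 2 (0.28 log units; within the scatter). That step exchanged methyl for pyridin-2-yl and moved the number no more than repeat measurements would. It is thin evidence for a new kind of group, but it gives no reason to expect a large shift in either direction. The expected change is only a 1.4-fold lower number from compound 2 to compound 3 (0.15 log units; within the scatter), which is no real step beyond the scatter. For compound 3 the estimated value in this assay is 30000 nM, with an expected range from 12000 nM to 70000 nM.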

Compound 3, half-maximal inhibitory concentration: 6070 nM
Compound 3: middle estimate off by 4.9-fold (0.69 log units), on the high side, outside the stated range (below it).
By their numbers in this assay, from the lowest: compound 3; then compounds 1 and 2 (each within the scatter of the next).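

In this assay, the group on this ring nitrogen can matter after all: tert-butoxycarbonyl in place of pyridin-2-yl gives a clear step (a 6.9-fold lower number from compound 2 to compound 3 (0.84 log units; beyond the scatter)), and tert-butoxycarbonyl in place of methyl gives another (a 3.6-fold lower number from compound 1 to compound 3 (0.56 log units; beyond the scatter)). Compound 3 thus stands apart from both earlier compounds, which lie within the scatter of each other, so the similar results for methyl and pyridin-2-yl did not mean that every group here behaves alike. No measured evidence explains this shift.

From the compounds shown here alone, it remains open whether the lower number comes with the carbonyl and its oxygen or with the tert-butyl end of the new group. An acetyl group or a methoxycarbonyl group on the same nitrogen would help to separate these parts.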